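Cyanophenyl in Place of Cyclohexenyl on a Shared Core

The compounds below may be only part of what the source reports. "The series", "measured", "known", "first", "only" and "open" are said of these compounds alone.

Of the compounds shown here, three of a shared core have been measured in a functional assay for agonist activity at G protein-coupled receptor 88 (Homo sapiens), read by HTRF and cAMP accumulation; a lower number here means that less compound is needed, a higher number that more compound is needed for the effect. Compound 1 `CC[C@H](C)[C@H](N)CN(C(=O)[C@@H]1C[C@H]1c1cccc(Cl)c1)c1ccc(-c2ccccc2)cc1` gives 2200 nM, and compound 2 `CC[C@H](C)[C@H](N)CN(C(=O)[C@@H]1C[C@H]1c1cc(F)cc(F)c1)c1ccc(-c2ccccc2)cc1` gives 960 nM, a change described by a 2.3-fold lower number from compound 1 to compound 2 (0.36 log units; beyond the scatter). Compound 3 `CC(C)C[C@H](N)CN(C(=O)[C@@H]1C[C@H]1c1ccccc1)c1ccc(C2=CCCCC2)cc1` gives 1200 nM, the second highest of the three numbers; its gaps to compound 2 and to compound 1 both lie within the scatter. Compound 4 `CC(C)C[C@H](N)CN(C(=O)[C@@H]1C[C@H]1c1ccccc1)c1ccc(-c2cccc(C#N)c2)cc1` differs from compound 3 by 3-cyanophenyl in place of cyclohex-1-en-1-yl on an aromatic carbon. Among the measured compounds shown here, no measured step concerns this part of the core, so the comparison of compound 1 with compound 2 offers no guide here. Compound 4 is therefore expected to show a 1.2-fold lower number from compound 3 to compound 4 (0.08 log units; within the scatter), with an estimate of 1000 nM between 350 nM and 3000 nM.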

Compound 4, half-maximal effective concentration: 4500 nM
Compound 4: middle estimate off by 4.5-fold (0.65 log units), on the low side; measured number above the stated range.
By their numbers in this assay, from the lowest: compounds 2, 3 and 1 (each within the scatter of the next, the first and the last beyond it); then compound 4.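

In this assay, the aromatic carbon para to a large group proves responsive to what it carries: 3-cyanophenyl in place of cyclohex-1-en-1-yl gives a 3.8-fold higher number from compound 3 to compound 4 (0.57 log units; beyond the scatter). Among the compounds shown here, the earlier step concerned only the aryl group on the saturated ring carbon, so this is the first reading at this position, and the number moves upward. Nothing available explains the rise.

The compounds shown leave open whether the rise follows the nitrile or the aromatic ring that carries it. On these data alone, how an unsubstituted phenyl or a 3-aminophenyl would read on the core of compound 3 also remains open.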